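The source may report more compounds than this note shows. Statements on the series, on what has been measured and on what is new or still open speak of the compounds shown alone.

Measured so far:
compound 1 `CCOc1ccccc1C(=O)/C=C/c1ccc2ccccc2c1`, 7800 nM
compound 2 `CCCCOc1ccccc1C(=O)/C=C/c1ccc2ccccc2c1`, > 100000 nM

In an ADME assay on M210B4 cells (Mus musculus) for cytotoxicity, with a stated time of 48 h (on this read-out lower numbers stand for stronger inhibition and higher numbers for weaker inhibition), compound 1 gives 7800 nM, the only plain number shown. Compound 2 reaches only a limit of the assay, > 100000 nM. Compound 3 `CC(C)Oc1ccccc1C(=O)/C=C/c1ccc2ccccc2c1` differs from compound 1 by methyl in place of hydrogen on a saturated chain carbon bound to an oxygen on an aromatic ring and a saturated chain carbon. Within the data shown here, the one measured step, an at least 12-fold higher number from compound 1 to compound 2 (1.10 log units; beyond the scatter), lengthens the same chain and weakens strongly, ending at the limit of > 100000 nM in this assay, at which 1 of the 2 values shown sits. A shorter branch on the carbon bound to the oxygen is expected to weaken less, so the estimated step is a 2.6-fold higher number from compound 1 to compound 3 (0.41 log units; beyond the scatter). Compound 3 is therefore expected near 20000 nM, within 7000 nM to 100000 nM.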

Compound 3, half-maximal inhibitory concentration: > 100000 nM
Compound 3 was reported as a limit; the forecaster's own chance of this, stated with the estimate: 25%; middle value at least 5.0-fold (0.69 log units) from the limit.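

Adding a single methyl on the saturated chain carbon bound to the oxygen, which turns ethoxy into isopropoxy, gives an at least 12-fold higher number from compound 1 to compound 3 (1.10 log units; beyond the scatter). Among these compounds, a longer straight chain is therefore not the only change at this oxygen that raises the number so far. The step between compound 2 and compound 3 cannot be read, since both are limits and not numbers: the limit of > 100000 nM in this assay, at which 2 of the 3 values shown sit.

Still open, on these data alone, is whether a methoxy group or a straight propoxy chain would give a plain number in this assay. The same question stands for a chain carrying an amine.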